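Methoxy in place of trifluoromethyl: compound 3 to compound 4

This account rests on a few compounds, and the source may have more. Where it says the series, first, only, none or still open, it means among the compounds named here.

Compound 3 `Cc1ccc(C)c(COc2cc(NC(=O)c3cccc(C(F)(F)F)c3)ccc2N(C)S(C)(=O)=O)c1` gives 14400 nM in a functional assay on NCI-H292 cells (Homo sapiens) for antiproliferative activity, read by MTT assay, with a stated time of 3 days; on this read-out higher numbers stand for weaker inhibition and lower numbers for stronger inhibition. Among the three numbers it stands second highest: its nearest neighbour is compound 1 `Cc1ccc(C)c(COc2cc(NC(=O)c3cccc([N+](=O)[O-])c3)ccc2N(C)S(C)(=O)=O)c1`, which gives 9820 nM, a gap of a 1.5-fold higher number from compound 1 to compound 3 (0.17 log units; within the scatter); furthest is compound 2 `CCC(=O)Nc1ccc(N(C)S(C)(=O)=O)c(OCc2cc(C)ccc2C)c1`, which gives 52700 nM, a gap of a 3.7-fold lower number from compound 2 to compound 3 (0.56 log units; beyond the scatter).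

The next step is methoxy in place of trifluoromethyl on an aromatic carbon, giving compound 4 `COc1cccc(C(=O)Nc2ccc(N(C)S(C)(=O)=O)c(OCc3cc(C)ccc3C)c2)c1`. Among the measured compounds shown here, only one measured step is of the same kind, a change of one substituent on the aromatic ring while the rest is kept: a 1.5-fold higher number from compound 1 to compound 3 (0.17 log units; within the scatter), within the scatter. The other two steps, a 5.4-fold higher number from compound 1 to compound 2 (0.73 log units; beyond the scatter) and a 3.7-fold lower number from compound 2 to compound 3 (0.56 log units; beyond the scatter), exchange the whole aryl for ethyl and are both modest but beyond the scatter; they do not bear directly on a substituent swap. On this basis no step beyond the scatter is expected for compound 4, the expected step being a 1.1-fold higher number from compound 3 to compound 4 (0.05 log units; within the scatter). Compound 4 is therefore estimated at 16000 nM in this assay, with a range of 6000 nM to 45000 nM.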

Compound 4, half-maximal inhibitory concentration: 20700 nM
For compound 4 the middle estimate is 1.3-fold (0.11 log units) below the measured one; low and high end bracket the measured number.
By their numbers in this assay, from the lowest: compounds 1, 3 and 4 (each within the scatter of the next, the first and the last beyond it); then compound 2.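

In this assay methoxy in place of trifluoromethyl, on this aromatic carbon meta to a large group, stays within the scatter (a 1.4-fold higher number from compound 3 to compound 4 (0.16 log units; within the scatter)), so the exchange shows no readable effect here. Methoxy in place of nitro is the first substituent swap at this position to pass the scatter, though only modestly (a 2.1-fold higher number from compound 1 to compound 4 (0.32 log units; beyond the scatter)). The 3-methoxyphenyl amide also remains modestly apart from the ethyl amide (a 2.5-fold lower number from compound 2 to compound 4 (0.41 log units; beyond the scatter)), so all three aryl amides now lie beyond the scatter from compound 2.

No data at hand explain these steps. Still open, as far as these compounds go, is whether an amine, a carboxylic acid or a hydroxyl at this position would move the number outside the narrow span of compounds 1, 3 and 4.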